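Alkynyl uracil phthalimides: double-bond geometry and chain terminus

A few compounds are considered here, and "the series" means these few. Any claim that something is new, unique, unknown or untested is made for them only; others in the source may bear on it.

Compound 2 `O=C1c2ccccc2C(=O)N1C/C=C\Cn1cc(C#CCCc2ccccc2)c(=O)[nH]c1=O` and compound 3 `O=C1c2ccccc2C(=O)N1C/C=C/Cn1cc(C#CCCc2ccccc2)c(=O)[nH]c1=O` share every atom and bond; their cores differ only as counted in the two compounds have the same atoms and bonds and differ only in configuration as drawn: 1 of 1 stereo elements differ; a double bond is drawn Z in compound 2 and E in compound 3. In a functional assay on SW-620 cells (Homo sapiens) for antiproliferative activity, read by MTT assay, with a stated time of 3 days (a higher number here means a weaker inhibitor, a lower number a stronger inhibitor), compound 2 gives only a limit of the assay, > 100000 nM. Compound 3 gives 11000 nM, so an at least 9.0-fold lower number from compound 2 to compound 3 (0.95 log units; beyond the scatter). Compound 1 `CCCCC#Cc1cn(C/C=C\CN2C(=O)c3ccccc3C2=O)c(=O)[nH]c1=O` carries ethyl in place of phenyl on a saturated chain carbon, two bonds along the chain from a triple-bonded carbon and gives 82000 nM in this assay. The step is an at least 1.2-fold lower number from compound 2 to compound 1 (0.08 log units; that floor lies within the scatter); its floor is set by the limit of > 100000 nM in this assay, at which 1 of the 3 values shown sits, which is the limit of compound 2. Compound 4 `CCCCC#Cc1cn(C/C=C/CN2C(=O)c3ccccc3C2=O)c(=O)[nH]c1=O` applies ethyl in place of phenyl on a saturated chain carbon, two bonds along the chain from a triple-bonded carbon to compound 3, the same change as that between compound 2 and compound 1, at the same place. Compound 4 is expected to show a step of about a 1.1-fold lower number from compound 3 to compound 4 (0.04 log units; within the scatter), since the corresponding measured step of an at least 1.2-fold lower number from compound 2 to compound 1 (0.08 log units; that floor lies within the scatter) rests on a limit and allows little more than a small change. Compound 4 is therefore estimated at 10000 nM in this assay, between 3000 nM and 40000 nM.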

Compound 4, half-maximal inhibitory concentration: > 100000 nM
Compound 4: a limit, no number; the forecaster's own chance of this, stated with the estimate: 5%; middle value at least 10-fold (1.00 log units) away from the limit.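

Compound 4 gives only a limit of this assay, > 100000 nM.

Phenyl to ethyl on the core with the E double bond weakens the compound, an at least 9.0-fold higher number from compound 3 to compound 4 (0.95 log units; beyond the scatter), so this change does not carry over as one fixed step from the core with the Z double bond: the same change on two cores in this assay, an at least 1.2-fold lower number (0.08 log units; that floor lies within the scatter) from compound 2 to compound 1 and an at least 9.0-fold higher number (0.95 log units; beyond the scatter) from compound 3 to compound 4, at least 11-fold (1.04 log units) apart, beyond the scatter of two such steps

The Z to E step on the ethyl compounds, an at least 1.2-fold higher number from compound 1 to compound 4 (0.08 log units; that floor lies within the scatter), has a floor within the scatter, and the true sizes of the steps that rest on a limit remain unknown: the limit of > 100000 nM in this assay, at which 2 of the 4 values shown sit.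

Open, on these data alone, is whether the phenyl group is specifically required for the activity of compound 3 on the E core. Also open, as far as these compounds go, is whether a longer chain or an amine in place of phenyl would keep that activity.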